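Side-chain replacement on the five-membered ring: estimate for compound 4

This account rests on a few compounds, and the source may have more. Where it says the series, first, only, none or still open, it means among the compounds named here.

Measured so far:
compound 1 `NS(=O)(=O)c1cc(-c2nnc(Cn3cc(-c4ccccc4)nn3)o2)c(Cl)cc1SCc1ccccc1`: in a functional assay on HeLa cells (Homo sapiens) for cytotoxicity, read by MTT assay, with a stated time of 72 h (a higher number here means a weaker inhibitor, a lower number a stronger inhibitor), compound 1 gives 7000 nM
compound 2 `NS(=O)(=O)c1cc(-c2nnc(CNC(=O)c3ccccc3)o2)c(Cl)cc1SCc1ccccc1`: compound 2 gives 105000 nM
compound 3 `NS(=O)(=O)c1cc(-c2nnc(CNS(=O)(=O)c3ccc(Cl)cc3)o2)c(Cl)cc1SCc1ccccc1`: compound 3 gives 24000 nM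

Compound 3 sits second highest of the three numbers: a 3.4-fold higher number from compound 1 to compound 3 (0.54 log units; beyond the scatter), and a 4.4-fold lower number from compound 2 to compound 3 (0.64 log units; beyond the scatter). All three measured steps change the same position, and that position is sensitive, as shown by a 15-fold higher number from compound 1 to compound 2 (1.18 log units; beyond the scatter).

Compound 4 `NS(=O)(=O)c1cc(-c2nnc(/C=C/c3ccccc3)o2)c(Cl)cc1SCc1ccccc1` differs from compound 3 by 2-phenylethenyl in place of (((4-chlorophenyl)sulfonyl)amino)methyl on an aromatic carbon. For the measured compounds named here, no measured step covers this exact change; the closest information is that compound 1, which carries an aromatic group without hydrogen-bond donors at this position, gives the lowest number of the three. A modest step to a lower number is therefore expected for compound 4, a 2.4-fold lower number from compound 3 to compound 4 (0.38 log units; beyond the scatter). Compound 4 is estimated at 10000 nM, with a range from 3000 nM to 35000 nM.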

Compound 4, half-maximal inhibitory concentration: 14000 nM
Compound 4: middle estimate off by 1.4-fold (0.15 log units), on the low side; the range from low to high includes it.
By their numbers in this assay, from the lowest: compounds 1, 4 and 3 (each within the scatter of the next, the first and the last beyond it); then compound 2.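

In this assay, 2-phenylethenyl on this aromatic carbon gives a 1.7-fold lower number from compound 3 to compound 4 (0.23 log units; within the scatter) and a 2.0-fold higher number from compound 1 to compound 4 (0.30 log units; within the scatter), so removing the sulfonamide hydrogen-bond donor and the saturated chain carbon does not separate compound 4 from compound 3. Only the benzamidomethyl group stands apart, with a 7.5-fold lower number from compound 2 to compound 4 (0.88 log units; beyond the scatter). No supporting data explain this difference.

Every side chain shown ends in an aromatic ring. From the compounds shown here alone, whether that ring is needed remains open, as does whether a primary amine or a carboxylic acid on a short chain would fall with compound 4 or with compound 2.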